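Replacing the 3,4-dimethoxyphenyl group on the nitrogen

A few compounds are considered here, and "the series" means these few. Any claim that something is new, unique, unknown or untested is made for them only; others in the source may bear on it.

- compound 1 `CCS(=O)(=O)Nc1cc(-c2ccc3ncnc(Nc4ccc(OC(F)(F)F)cc4)c3c2)cnc1OC`: 8240 nM
- compound 2 `CCS(=O)(=O)Nc1cc(-c2ccc3ncnc(Nc4ccc(OC)cc4)c3c2)cnc1OC`: 1880 nM
- compound 3 `CCS(=O)(=O)Nc1cc(-c2ccc3ncnc(Nc4ccc(OC)c(OC)c4)c3c2)cnc1OC`: 2590 nM
- compound 4 `CCS(=O)(=O)Nc1cc(-c2ccc3ncnc(Nc4ccc(Cl)c(C(=O)OC)c4)c3c2)cnc1OC`: not yet measured

In a functional assay on BT-549 cells (Homo sapiens) for cytotoxicity, read by sulforhodamine B assay, with a stated time of 72 h (a higher number here means a weaker inhibitor, a lower number a stronger inhibitor), compound 3 gives 2590 nM, the second highest of the three numbers, though a 1.4-fold higher number from compound 2 to compound 3 (0.14 log units; within the scatter) leaves it indistinguishable from compound 2. The next change is 4-chloro-3-(methoxycarbonyl)phenyl in place of 3,4-dimethoxyphenyl on a nitrogen on an aromatic ring, which puts 4-chloro-3-(methoxycarbonyl)phenyl in place of 3,4-dimethoxyphenyl on a nitrogen on an aromatic ring. For the measured compounds named here, no measured compound carries chloro or methoxycarbonyl, so the guide is indirect. Going by the values given here, the closest precedent is the other exchange of a whole group at this place, a 3.2-fold lower number from compound 1 to compound 3 (0.50 log units; beyond the scatter), and a 4.4-fold lower number from compound 1 to compound 2 (0.64 log units; beyond the scatter) runs the same way. Compound 4 keeps neither methoxy group of compound 3, and compound 1 also has neither, so a modest rise in the number is expected, of about the size of those steps or smaller. The expected change is a 2.1-fold higher number from compound 3 to compound 4 (0.33 log units; beyond the scatter). For compound 4 the estimated value is 5500 nM, with an expected range of 2000 nM to 14000 nM.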

Compound 4, half-maximal inhibitory concentration: 2360 nM
Estimate against measurement, compound 4: 2.3-fold (0.37 log units) above; the measured number falls inside the stated range.
By their numbers in this assay, from the lowest: compounds 2, 4 and 3 (each within the scatter of the next); then compound 1.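

In this assay, the 4-chloro-3-(methoxycarbonyl)phenyl group on the nitrogen cannot be told apart from either methoxy-bearing group: a 1.1-fold lower number from compound 3 to compound 4 (0.04 log units; within the scatter) and a 1.3-fold higher number from compound 2 to compound 4 (0.10 log units; within the scatter) both lie within the scatter. The absence of a methoxy group therefore does not by itself bring the higher number of compound 1, since a 3.5-fold lower number from compound 1 to compound 4 (0.54 log units; beyond the scatter) lies beyond the scatter, and among the four compounds only the 4-(trifluoromethoxy)phenyl compound stands apart. Nothing measured here bears on the reason for this.

From the compounds shown here alone, compound 4 carries chloro and methoxycarbonyl together, so the contribution of each remains open. Also open, going by these compounds, is how a carboxylic acid or a primary amide in place of the methoxycarbonyl, or an amine on the same ring, would read in this assay.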